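The compounds below may be only part of what the source reports. "The series", "measured", "known", "first", "only" and "open" are said of these compounds alone.

Measured compounds in a functional assay on cells for positive allosteric modulation of metabotropic glutamate receptor 2 (Homo sapiens), read by scintillation counting and GTPgammaS binding, with a stated time of 30 min; on this read-out lower numbers stand for an effect already at smaller amounts and higher numbers for an effect only at larger amounts of compound:
- compound 1 `Clc1cc(-c2ccn3c(CC4CC4)nnc3c2Cl)ccc1NC1CC1`: 29.5 nM
- compound 2 `Clc1cc(-c2ccn3c(CC4CC4)nnc3c2Cl)ccc1OC1CCOCC1`: 224 nM
- compound 3 `FC(F)(F)c1c(-c2ccc(OC3CCOCC3)c(Cl)c2)ccn2c(CC3CC3)nnc12`: 38 nM

Compound 2 carries the highest number of the three. Its nearest neighbour is compound 3, reached by a 5.9-fold lower number from compound 2 to compound 3 (0.77 log units; beyond the scatter); its furthest is compound 1, from which a 7.6-fold higher number from compound 1 to compound 2 (0.88 log units; beyond the scatter) leads to compound 2. Both steps lie beyond the scatter, so compound 2 is the weakest of the measured set on this read-out.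

Compound 4 `Clc1cc(-c2ccn3c(CC4CC4)nnc3c2Cl)ccc1NC1CCOCC1` is not yet measured. It differs from compound 2 in one place: (oxan-4-yl)amino in place of (oxan-4-yl)oxy on an aromatic carbon. For the measured compounds named here, only one measured step touches this position, a 7.6-fold higher number from compound 1 to compound 2 (0.88 log units; beyond the scatter), and there the ring and the linking atom changed together, so the contribution of the linking atom alone cannot be separated from the data. The step from compound 2 to compound 4 keeps the oxan-4-yl ring and changes only the linker, from ether oxygen to amine nitrogen; the comparison with compound 1 suggests the amine-linked form gives the lower number. A modest step downward is therefore expected, smaller than the whole of a 7.6-fold higher number from compound 1 to compound 2 (0.88 log units; beyond the scatter), as a 3.2-fold lower number from compound 2 to compound 4 (0.51 log units; beyond the scatter). The estimate for compound 4 in this assay is 70 nM, with a range from 25 nM to 200 nM.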

Compound 4, half-maximal effective concentration: 148 nM
The estimate for compound 4 lay 2.1-fold (0.33 log units) below the measured number; the range from low to high includes it.
By their numbers in this assay, from the lowest: compounds 1 and 3 (each within the scatter of the next); then compounds 4 and 2 (each within the scatter of the next).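

In this assay, putting the amine nitrogen in place of the ether oxygen under the oxan-4-yl ring gives no readable difference: a 1.5-fold lower number from compound 2 to compound 4 (0.18 log units; within the scatter). With the nitrogen held constant, the group on it does matter, a 5.0-fold higher number from compound 1 to compound 4 (0.70 log units; beyond the scatter), so most of a 7.6-fold higher number from compound 1 to compound 2 (0.88 log units; beyond the scatter) goes with oxan-4-yl in place of cyclopropyl and not with the linking atom, a reading confined to these compounds. Nothing available bears on the origin of either step.

The compounds shown leave open whether a cyclopropyl on the ether oxygen would stand with compound 1 or with compound 2, and whether other groups on the nitrogen, such as a methyl, an isopropyl or a cyclobutyl, would follow the cyclopropyl or the oxan-4-yl. They also leave open whether the gain from trifluoromethyl in place of chloro, a 5.9-fold lower number from compound 2 to compound 3 (0.77 log units; beyond the scatter), carries over to the amine-linked compound 1 and compound 4.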